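A few compounds are considered here, and "the series" means these few. Any claim that something is new, unique, unknown or untested is made for them only; others in the source may bear on it.

Measured so far:
compound 1, `Cc1nn(-c2ncnc3nc[nH]c23)c2c1C(OCc1ccccc1Cl)CC(=O)N2`: 47 nM
compound 2, `Cc1cc(C)nc(-n2nc(C)c3c2NC(=O)CC3c2ccc(F)cc2F)n1`
compound 3, `Cc1nn(-c2ncnc3nc[nH]c23)c2c1C(C(=O)NCc1ccc(F)cc1)CC(=O)N2`: 1220 nM

In a functional assay on HEK293 cells for agonist activity at G-protein coupled receptor 39 (Homo sapiens), read by scintillation proximity assay and inositol phosphate accumulation, with a stated time of 75 min (a higher number here means that more compound is needed for the effect, a lower number that less compound is needed), compound 1 gives 47 nM, the lowest of the two numbers reported. Compound 3 gives 1220 nM, a gap from compound 1 that lies beyond the scatter. For compound 2 only a limit of the assay is recorded, > 10000 nM; it is a limit and not a number, and of the three values shown one sits at it (the limit of > 10000 nM in this assay, at which 1 of the 3 values shown sits). Compound 2 also differs from the other two in more than one place, so its value shows only that it reached the limit.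

The next compound, compound 4, `CCCCCCCCOC1CC(=O)Nc2c1c(C)nn2-c1ncnc2nc[nH]c12`, differs from compound 1 in one place:
heptyl in place of 2-chlorophenyl on a saturated chain carbon bound to an oxygen on a saturated carbon
Among the compounds with values here, no pair of measured compounds differs in just one place, so no measured step gives a scale for this change. The ether oxygen and the rest of the core of compound 1 are kept; an aromatic ring leaves and a flexible chain of the same heavy-atom count enters. The expectation is that the step of a 6.4-fold higher number from compound 1 to compound 4 (0.81 log units; beyond the scatter) goes toward a higher number in this assay, of moderate size, with a real chance of falling within the scatter. Compound 4 is estimated at 300 nM, within 60 nM to 3000 nM.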

Compound 4, half-maximal effective concentration: 388 nM
Compound 4: the middle estimate sits 1.3-fold (0.11 log units) below what was measured, within the range that was stated.
By their numbers in this assay, from the lowest: compound 1; then compound 4; then compound 3. At a limit, above all of these: compound 2.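

The heptyl-for-2-chlorophenyl change gives the series its first single-place step, an 8.3-fold higher number from compound 1 to compound 4 (0.92 log units; beyond the scatter), and so a first scale for the group carried on the ether oxygen. In this assay, this one pair shows that an aromatic ring in this place is not needed for a measurable effect: compound 1, with its 2-chlorobenzyl ether, keeps the lower number, while compound 4, with an octyl ether that has no ring and the same count of heavy atoms in the exchanged group, still gives 388 nM. Nothing measured on these compounds bears on why the number moves in this step.

The ring and the chlorine leave together in this change, so the compounds shown cannot separate the share of each in the step, and a single pair says nothing yet about a trend with chain length or shape at this position. On these data alone, how an unsubstituted benzyl group, a shorter butyl chain, or an octyl chain ending in an amine or a carboxylic acid would read on the same ether oxygen remains open.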